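Swapping the benzyl ring substituents in a benzothiazole amide series

This account rests on a few compounds, and the source may have more. Where it says the series, first, only, none or still open, it means among the compounds named here.

Of the compounds shown here, two of a shared core have been measured in a functional assay on PC-3 cells (Homo sapiens) for antiproliferative activity, read by MTT assay, with a stated time of 48 h; on this read-out lower numbers stand for stronger inhibition and higher numbers for weaker inhibition. Compound 1 `COc1ccc(CN(C(=O)CSc2nc3ccccc3s2)c2cc(OC)c(OC)c(OC)c2)cc1O` gives 2110 nM, and compound 2 `COc1ccc(CN(C(=O)CSc2nc3ccccc3s2)c2cc(OC)c(OC)c(OC)c2)cc1Br` gives 16000 nM. Among the compounds with values here, on these two numbers compound 2 stands at the highest, meaning the weaker of the pair, and its only neighbour is compound 1, reached through a single step: a 7.6-fold higher number from compound 1 to compound 2 (0.88 log units; beyond the scatter).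

Compound 3 `COc1cc(N(Cc2ccc(Cl)cc2)C(=O)CSc2nc3ccccc3s2)cc(OC)c1OC` differs from compound 2 in one place. 4-chlorophenyl in place of 3-bromo-4-methoxyphenyl on a saturated chain carbon bound to an amide-type nitrogen

Within the data shown here, no measured step covers this exact exchange, so the expectation rests only on the one step in hand. That step shows that a change of substituent on this same ring, bromo in place of hydroxy, moved the number well beyond the scatter, so another change on this ring may also move it, yet the direction cannot be read from one step. Compound 3 is therefore estimated near 9000 nM, with a range of 2500 nM to 32000 nM, which means an expected step of a 1.8-fold lower number from compound 2 to compound 3 (0.25 log units; within the scatter).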

Compound 3, half-maximal inhibitory concentration: > 80000 nM
Compound 3: no number, only a limit; the forecaster's own chance of this, stated with the estimate: 10%; at least 8.8-fold (0.94 log units) between middle value and limit.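

Compound 3 gives no number in this assay, only a limit: the limit of > 80000 nM in this assay, at which 1 of the 3 values shown sits.

The earlier pair showed that one substituent on this benzyl ring can shift the result, and compound 3 shows that replacing the whole ring pattern can shift it much further, with an at least 5.0-fold higher number from compound 2 to compound 3 (0.69 log units; beyond the scatter) and, measured against the hydroxy compound, an at least 37-fold higher number from compound 1 to compound 3 (1.57 log units; beyond the scatter). So this position is far from indifferent to what it carries: among the three compounds, the ring of compound 1, with its hydroxy and methoxy groups, gives the lowest number, and the 4-chlorophenyl ring of compound 3 stands at the far end.

The exchange alters more than one feature at once, since the methoxy group goes, the bromine goes and a chlorine enters, so these compounds cannot tell which of those changes carries the loss. Also open, on these data alone, is how this position would respond to a ring keeping the methoxy group while carrying an amine or a carboxylic acid in place of the hydroxy or bromo group, or to a plain unsubstituted benzyl group.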